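Chloro for methyl on the pendant aryl ring

A few compounds are considered here, and "the series" means these few. Any claim that something is new, unique, unknown or untested is made for them only; others in the source may bear on it.

Working notes on a small series of sulfonamides sharing one core. Compound 1 `Cc1ccccc1-n1cc(-c2ccccc2NS(=O)(=O)c2c[nH]c(=O)[nH]c2=O)nn1`, compound 2 `O=c1[nH]cc(S(=O)(=O)Nc2ccccc2-c2cn(-c3ccc(F)cc3)nn2)c(=O)[nH]1` and compound 3 `Cc1ccc(-n2cc(-c3cccc(NS(=O)(=O)c4c[nH]c(=O)[nH]c4=O)c3)nn2)cc1` have been run in an ADME assay on GES1 cells (Homo sapiens) for cytotoxicity, read by MTT assay, with a stated time of 24 h; on this read-out lower numbers stand for higher toxicity in this test and higher numbers for lower toxicity in this test. In this assay compound 3 gives 15800 nM, and compound 1 gives 19900 nM, a gap between the two that lies within the usual scatter, so neither can be set apart from the other. Compound 2 is reported in this assay only as "not toxic" (no number reported), with no number attached. Within the data shown here, no pair of measured compounds differing in a single place is available, so no measured step guides the next compound.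

Compound 4 `O=c1[nH]cc(S(=O)(=O)Nc2cccc(-c3cn(-c4ccc(Cl)cc4)nn3)c2)c(=O)[nH]1` differs from compound 3 by chloro in place of methyl on an aromatic carbon. With nothing measured for such a swap in this series, the step from compound 3 to compound 4 in this assay is expected to be small and of no clear direction, estimated at a 1.1-fold lower number from compound 3 to compound 4 (0.02 log units; within the scatter). Compound 4 is therefore expected to give about 15000 nM in this assay, within a range of 7000 nM to 35000 nM.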

Compound 4, half-maximal cytotoxic concentration: 11300 nM
Compound 4: the middle estimate sits 1.3-fold (0.12 log units) above what was measured, and the stated range covers the measured number.
By their numbers in this assay, from the lowest: compounds 4, 3 and 1 (each within the scatter of the next).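

Among these compounds, the first step between compounds differing in one place is now available: in this assay, the change from 4-methylphenyl to 4-chlorophenyl gives a 1.4-fold lower number from compound 3 to compound 4 (0.15 log units; within the scatter), which lies within the usual scatter. At this aromatic carbon, para to a large group, chloro in place of methyl therefore gives no change that can be told apart in this test. No measurement available here bears on the reason for this result.

On these data alone, whether a methoxy group or an amine at the same place would stay within the scatter of compound 3 remains open. Also open, as far as these compounds go, is whether chloro in place of methyl would read the same way on the pendant ring of compound 1, where the methyl group sits at a different place.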